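A Methyl Shift Tested Twice in HepG2 Cells

The source may report more compounds than this note shows. Statements on the series, on what has been measured and on what is new or still open speak of the compounds shown alone.

Compound 1 `Cc1cccc(-n2cc(-c3ccccc3NS(=O)(=O)c3c[nH]c(=O)[nH]c3=O)nn2)c1`: 3620 nM
Compound 2 `Cc1ccc(-n2cc(-c3ccccc3NS(=O)(=O)c3c[nH]c(=O)[nH]c3=O)nn2)cc1`: 8350 nM
Compound 3 `Cc1cccc(-n2cc(-c3ccc(NS(=O)(=O)c4c[nH]c(=O)[nH]c4=O)cc3)nn2)c1`: only a limit, > 20000 nM

In a functional assay on HepG2 cells (Homo sapiens) for antiproliferative activity, read by MTT assay, with a stated time of 24 h (on this read-out higher numbers stand for weaker inhibition and lower numbers for stronger inhibition), compound 1 gives 3620 nM, while compound 2 gives 8350 nM. The change between them is 4-methylphenyl in place of 3-methylphenyl on an aromatic nitrogen, and it produced a 2.3-fold higher number from compound 1 to compound 2 (0.36 log units; beyond the scatter). Compound 3 carries a different core; how its core differs from that of compound 1 is not broken down here. In this assay compound 3 reaches only a limit, > 20000 nM, meaning the assay reports no number for it. That value sits at the limit of > 20000 nM in this assay, at which 1 of the 3 values shown sits.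

Compound 4 `Cc1ccc(-n2cc(-c3ccc(NS(=O)(=O)c4c[nH]c(=O)[nH]c4=O)cc3)nn2)cc1` has not yet been measured. For the measured compounds named here, it differs from compound 3 by 4-methylphenyl in place of 3-methylphenyl on an aromatic nitrogen, the same change as the one that turns compound 1 into compound 2. Because the earlier step gave a 2.3-fold higher number from compound 1 to compound 2 (0.36 log units; beyond the scatter), the same change on the core of compound 3 is expected to push the number further in the same direction. Since compound 3 already stands at a limit, the most likely outcome for compound 4 is again a limit rather than a number. The expected step is a step that the limit leaves unreadable from compound 3 to compound 4. Compound 4 is estimated at 45000 nM, with the expected range running from 15000 nM to 150000 nM.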

Compound 4, half-maximal inhibitory concentration: 11600 nM
Compound 4: the middle estimate sits 3.9-fold (0.59 log units) above what was measured, outside the stated range (below it).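

In this assay, 4-methylphenyl in place of 3-methylphenyl gave an at least 1.7-fold lower number from compound 3 to compound 4 (0.23 log units; that floor lies within the scatter) on the second core, which is the opposite direction to the rise seen on the first core: the same change on two cores in this assay, a 2.3-fold higher number (0.36 log units; beyond the scatter) from compound 1 to compound 2 and an at least 1.7-fold lower number (0.23 log units; that floor lies within the scatter) from compound 3 to compound 4, at least 3.9-fold (0.59 log units) apart, beyond the scatter of two such steps

Compound 3 is recorded only as a limit, > 20000 nM, so the size of this step is a floor and not a measured figure. The result shows that, in this series, a step measured on one core cannot simply be carried over as a forecast for the other, but two pairs of compounds set no general rule and do not show why the two cores behave differently.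

The compounds shown carry only a methyl group on the phenyl ring attached to the aromatic nitrogen, so it remains open how each core would respond to a chlorine atom, a methoxy group or a longer chain such as ethyl in the same two positions. From the compounds shown here alone, it also remains open whether the reversal seen with the methyl shift would appear again with any of those groups, or would stay confined to this one pair of methylphenyl isomers.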